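Methyl-to-hydrogen steps in a hydroxamate-bearing aniline series

A few compounds are considered here, and "the series" means these few. Any claim that something is new, unique, unknown or untested is made for them only; others in the source may bear on it.

Compound 1 `COc1cc2c(Oc3ccc(NC(=O)c4nn(-c5ccccc5C)cc(C)c4=O)cc3)ccnc2cc1OCCCCCC(=O)NO` gives 1820 nM in a functional assay on A549 cells (Homo sapiens) for inhibition, read by MTT assay, with a stated time of 72 h; a lower number here means a stronger inhibitor, a higher number a weaker inhibitor. Compound 2 `COc1cc2c(Oc3ccc(NC(=O)c4nn(-c5ccccc5C)ccc4=O)cc3)ccnc2cc1OCCCCCC(=O)NO` differs from it by hydrogen in place of methyl on an aromatic carbon, and in this assay compound 2 gives 3920 nM; the step is a 2.2-fold higher number from compound 1 to compound 2 (0.33 log units; beyond the scatter). Compound 3 `COc1cc2c(Oc3ccc(NC(=O)c4nn(-c5ccccc5C)cc(C)c4=O)cc3F)ccnc2cc1OCCCC(=O)NO` gives 2090 nM in this assay; the difference between the core of compound 3 and the core of compound 1 is not broken down here. Compound 4 `COc1cc2c(Oc3ccc(NC(=O)c4nn(-c5ccccc5)cc(C)c4=O)cc3F)ccnc2cc1OCCCC(=O)NO` is not yet measured and differs from compound 3 by hydrogen in place of methyl on an aromatic carbon. This is the same kind of change as that from compound 1 to compound 2, not the same: there the methyl left a six-membered aromatic ring with 2 nitrogen, here it leaves a six-membered aromatic ring of carbon only, ortho to a large group. Within the data shown here, because a 2.2-fold higher number from compound 1 to compound 2 (0.33 log units; beyond the scatter) was the only comparable step, a step of a 1.4-fold higher number from compound 3 to compound 4 (0.16 log units; within the scatter) is expected, with wide bounds. Compound 4 is expected to give 3000 nM, between 1400 nM and 6500 nM.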

Compound 4, half-maximal inhibitory concentration: 1900 nM
Beside the measured number, compound 4's estimate is 1.6-fold (0.20 log units) above it; low and high end bracket the measured number.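

In this assay the change from 2-methylphenyl to phenyl gives a 1.1-fold lower number from compound 3 to compound 4 (0.04 log units; within the scatter) and does not separate from the earlier methyl-to-hydrogen step: the same change on two cores in this assay, a 2.2-fold higher number (0.33 log units; beyond the scatter) from compound 1 to compound 2 and a 1.1-fold lower number (0.04 log units; within the scatter) from compound 3 to compound 4, 2.4-fold (0.37 log units) apart, within the scatter of two such steps

So the two steps give no sign that the size of this change depends on the core. Among these compounds, they do not show that it carries over unchanged either, as there are only two steps, the methyl leaves a different ring in each, and the two cores differ in more than this methyl.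

The compounds shown leave open what a chlorine or a methoxy group would give in place of this methyl on the phenyl ring. They also leave open whether the step holds with a longer chain carrying the hydroxamic acid.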